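The compounds below may be only part of what the source reports. "The series", "measured", "known", "first", "only" and "open" are said of these compounds alone.

Compound 1, `COC(=O)c1ccc(NCc2cncn2Cc2cccc(C)c2)cc1-c1ccccc1`, in a toxicity assay on NIH3T3 cells (Mus musculus) for cytotoxicity, read by resazurin assay (on this read-out higher numbers stand for an effect only at larger amounts of compound and lower numbers for an effect already at smaller amounts), gives > 10000 nM, which is a limit of the assay.
Compound 2, `c1ccc(Cn2cncc2CNc2cccc(-c3ccccc3)c2)cc1`, in this assay gives > 750 nM, again a limit of the assay.
Compound 3, `CC(C)c1ccc(Cn2cncc2CNc2ccc(-c3nc4ccccc4s3)c(-c3ccccc3)c2)cc1`, in this assay gives > 1000 nM, also a limit of the assay.

None of the three measured compounds has a number in this assay; each sits at a limit, so no ranking among them can be read from the data. Compound 1 stands at the limit of > 10000 nM in this assay, at which 1 of the 3 values shown sits, the widest of the three limits, and the other two compounds rest at the limit of > 750 nM in this assay, at which 1 of the 3 values shown sits, and (the limit of > 1000 nM in this assay, at which 1 of the 3 values shown sits). Within the data shown here, no pair of measured compounds differs in a single place, so there is no measured step to lean on.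

Compound 4, `COC(=O)c1ccc(NCc2cncn2Cc2cccc(C#N)c2)cc1-c1ccccc1`, is built from compound 1 by one change: cyano in place of methyl on an aromatic carbon. The swap touches only the outer end of the molecule, and compound 1 already shows no effect at its limit in this assay. The expectation is therefore that compound 4 also gives no effect within the tested range, so that the estimated step that the limit leaves unreadable from compound 1 to compound 4 stays within the scatter of the assay, with a good chance that only a limit is reported again. On that basis compound 4 is expected to give about 20000 nM in this assay, in the range 8000 nM to 60000 nM.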

Compound 4, half-maximal effective concentration: > 10000 nM
Compound 4: only a limit was reported; the forecaster's own chance of this, stated with the estimate: 80%; the middle value does not contradict the limit.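

Compound 1 and compound 4 rest at one and the same limit of the assay, not at a number: the limit of > 10000 nM in this assay, at which 2 of the 4 values shown sit. Among these compounds, no step from compound 1 to compound 4 can be read from them. The compounds shown leave open at what amount, if any, each would affect these cells, and whether cyano in place of methyl changes that.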